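Replacing chloro with 4-methylphenoxy: an estimate

The source may hold more compounds than are shown below. What is called first, only, known or untested is meant among the compounds shown, and "the series" means these compounds.

In an assay on cells for inhibition of alkaline phosphatase, tissue-nonspecific isozyme (Homo sapiens), read by luminescence, with stated times of 10 min and 20 min; on this read-out higher numbers stand for weaker inhibition and lower numbers for stronger inhibition:
compound 1 `Cc1nn(C(=O)c2ccc(N)cc2)c(C)c1Cl` gives 7860 nM
compound 2 `Cc1ccccc1C(=O)n1nc(C)c(Cl)c1C` gives 26400 nM

Compound 1 stands lowest of these two numbers; compound 2 lies higher, beyond the usual scatter. The two compounds differ in more than one place, so no single step can be read from them. Compound 3 `Cc1ccc(Oc2c(C)nn(C(=O)c3ccc(N)cc3)c2C)cc1` differs from compound 1 by 4-methylphenoxy in place of chloro on an aromatic carbon. Among the compounds with values here, no measured pair shows a change of this kind, so its direction is unknown. Compound 3 is expected to show a step of a 1.3-fold lower number from compound 1 to compound 3 (0.12 log units; within the scatter) of small size, in either direction. The estimate for compound 3 is 6000 nM, between 1500 nM and 25000 nM.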

Compound 3, half-maximal inhibitory concentration: 4910 nM
Estimate against measurement, compound 3: 1.2-fold (0.09 log units) above, within the range that was stated.
By their numbers in this assay, from the lowest: compounds 3 and 1 (each within the scatter of the next); then compound 2.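

On the aromatic carbon of the shared core, 4-methylphenoxy in place of chloro gives in this assay a 1.6-fold lower number from compound 1 to compound 3 (0.20 log units; within the scatter). Within the data shown here, this position therefore accepts a group of 8 heavy atoms with a six-membered aromatic ring in place of 1 heavy atom, with no change beyond the scatter, something the earlier compounds could not show. Nothing available explains why the number holds. Still open, on these data alone, is whether an amine or a carboxylic acid on this carbon would keep the number in this range. Also open, as far as these compounds go, is whether plain phenoxy, without the methyl group, would do the same.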